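Swapping a nitrophenyl for a bromophenyl in a naphthyloxy hydrazide series

The source may hold more compounds than are shown below. What is called first, only, known or untested is meant among the compounds shown, and "the series" means these compounds.

Measured compounds:
- compound 1 `O=C(COc1cccc2ccccc12)N/N=C/c1cccc([N+](=O)[O-])c1`: 12.1 ug/mL
- compound 2 `C/C(=N\NC(=O)COc1cccc2ccccc12)c1ccc([N+](=O)[O-])cc1`: 89.3 ug/mL
- compound 3 `COc1ccc(/C=N/NC(=O)COc2cccc3ccccc23)cc1`: 76.9 ug/mL

In an ADME assay on MT4 cells (Homo sapiens) for cytotoxicity, read by MTT assay, with a stated time of 4 days (on this read-out lower numbers stand for higher toxicity in this test and higher numbers for lower toxicity in this test), compound 2 gives the highest of the three numbers, meaning the lowest toxicity seen here. Compound 3 sits close behind, within the scatter, so the two cannot be told apart. Compound 1, by contrast, gives a clearly lower number, beyond the scatter, and is therefore the more toxic of the three.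

Compound 4 `C/C(=N\NC(=O)COc1cccc2ccccc12)c1ccccc1Br` has not yet been tested. It differs from compound 2 in one place: 2-bromophenyl in place of 4-nitrophenyl on a carbon with a double bond to nitrogen. Among the measured compounds shown here, no measured pair shows this kind of change, so its effect is unknown from the data; the only related hint is that compound 1, with a differently placed nitro group and without the methyl, is markedly more toxic than compound 2.

Compound 4 is expected to be somewhat more toxic than compound 2, with a step of a 1.5-fold lower number from compound 2 to compound 4 (0.17 log units; within the scatter) that may still fall within the scatter. The estimated value for compound 4 in this assay is 60 ug/mL, in a range from 25 ug/mL to 120 ug/mL.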

Compound 4, half-maximal cytotoxic concentration: 79.8 ug/mL
Estimate against measurement, compound 4: 1.3-fold (0.12 log units) below; the range from low to high includes it.
By their numbers in this assay, from the lowest: compound 1; then compounds 3, 4 and 2 (each within the scatter of the next).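

In this assay, 2-bromophenyl in place of 4-nitrophenyl on a carbon with a double bond to nitrogen gives a 1.1-fold lower number from compound 2 to compound 4 (0.05 log units; within the scatter), so compound 2 and compound 4 cannot be told apart. Among the compounds shown here, this is the first comparison here between two compounds that differ in one place only. It shows that this large change of group, with the nitro group gone and a bromine present at a different ring position, leaves the read-out without a clear shift. No measurement at hand explains why the number holds.

On these data alone, whether the result depends on where the halogen sits remains open, and 4-bromophenyl would test that directly. Also open, as far as these compounds go, is whether groups of another kind at this place, such as a 4-aminophenyl or a 4-carboxyphenyl, would keep the number or move it beyond the scatter.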